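A few compounds are considered here, and "the series" means these few. Any claim that something is new, unique, unknown or untested is made for them only; others in the source may bear on it.

Compound 2 `Nc1ncnc2c1c(-c1cnc3[nH]ccc3c1)nn2CC(=O)NO` and compound 1 `CNC(=O)CCCCCCCn1nc(-c2cnc3[nH]ccc3c2)c2c(N)ncnc21` share one core and differ in a single place: 6-(methylcarbamoyl)hexyl in place of hydroxycarbamoyl on a saturated chain carbon bound to an aromatic nitrogen. In a functional assay on CNE-2 cells (Homo sapiens) for inhibition, read by MTT assay, with a stated time of 72 h (on this read-out lower numbers stand for stronger inhibition and higher numbers for weaker inhibition), compound 2 gives only a limit, > 150000 nM. In this assay compound 1 gives 8990 nM, so the change brings an at least 16-fold lower number from compound 2 to compound 1 (1.22 log units; beyond the scatter). Compound 3 `Nc1nc2cc(-c3nn(CC(=O)NO)c4ncnc(N)c34)ccc2o1` carries a different core, and the difference between the two cores is not broken down here. In this assay compound 3 gives 12200 nM, within the scatter of compound 1. Compound 4 `CNC(=O)CCCCCCCn1nc(-c2ccc3oc(N)nc3c2)c2c(N)ncnc21` arises from compound 3 by the same change, (6-(methylcarbamoyl)hexyl in place of hydroxycarbamoyl on a saturated chain carbon bound to an aromatic nitrogen), at the same place. On these data alone, the measured step starts from a limit, which is all that the assay reports for compound 2 (the limit of > 150000 nM in this assay, at which 1 of the 3 values shown sits), so its full size stays open. Compound 4 is expected to give 3500 nM in this assay, an expected step of a 3.5-fold lower number from compound 3 to compound 4 (0.54 log units; beyond the scatter).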

Compound 4, half-maximal inhibitory concentration: 2250 nM
Compound 4: middle estimate off by 1.6-fold (0.19 log units), on the high side; the measured number falls inside the stated range.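

In this assay, the same change also lowers the number on the second core, with a 5.4-fold lower number from compound 3 to compound 4 (0.73 log units; beyond the scatter), so its direction carries over between these two cores. Its size does not carry over unchanged: the same change on two cores in this assay, an at least 16-fold lower number (1.22 log units; beyond the scatter) from compound 2 to compound 1 and a 5.4-fold lower number (0.73 log units; beyond the scatter) from compound 3 to compound 4, at least 3.0-fold (0.48 log units) apart, beyond the scatter of two such steps. On these data alone, the step from compound 2 starts from a limit, so how far apart the two steps really lie stays unknown: the limit of > 150000 nM in this assay, at which 1 of the 4 values shown sits.

Among the compounds shown here, with the 6-(methylcarbamoyl)hexyl chain kept, exchanging the aromatic group on the shared core gives a 4.0-fold lower number from compound 1 to compound 4 (0.60 log units; beyond the scatter), but only two such groups appear here. As far as these compounds go, whether a shorter or longer chain, or a carboxylic acid in place of the methylcarbamoyl end, would lower the number further stays open.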